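Cyclopropyl for chloro: working notes on compound 4

This account rests on a few compounds, and the source may have more. Where it says the series, first, only, none or still open, it means among the compounds named here.

Measured in an ADME assay on liver (Mesocricetus auratus) for metabolic stability, using microsomes; a lower number here means slower removal, a higher number faster removal of the compound:
- Compound 1 `O=C(NCc1ccccc1)Nc1[nH]nc(-c2ccccn2)c1Cl`: > 400 mL.min-1.g-1 (a limit, not a number)
- Compound 2 `O=C(Nc1cc(-c2ccccn2)n[nH]1)N1CCC(Oc2ccccc2)CC1`: 98.5 mL.min-1.g-1
- Compound 3 `O=C(Nc1cc(-c2ccccn2)n[nH]1)N1CCC(c2ccc(Cl)cc2)CC1`: 43.8 mL.min-1.g-1

Compound 1 stands at the limit of > 400 mL.min-1.g-1 in this assay, at which 1 of the 3 values shown sits, so it gives a limit and not a number. Compound 4 `O=C(NCc1ccccc1)Nc1[nH]nc(-c2ccccn2)c1C1CC1` differs from compound 1 by cyclopropyl in place of chloro on an aromatic carbon, with cyclopropyl in place of chloro on an aromatic carbon. Among the measured compounds shown here, the only measured step, a 2.2-fold lower number from compound 2 to compound 3 (0.35 log units; beyond the scatter), is a change on a saturated ring carbon, so it serves only as a rough guide to size. A modest step to a lower number in this assay, or none beyond the scatter, is therefore expected. Compound 4 is expected at 350 mL.min-1.g-1, with an estimated range of 150 mL.min-1.g-1 to 800 mL.min-1.g-1. The expected step is an at least 1.1-fold lower number from compound 1 to compound 4 (0.05 log units; that floor lies within the scatter).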

Compound 4, intrinsic clearance in microsomes: > 400 mL.min-1.g-1
Compound 4: only a limit was reported (the forecaster's own chance of this, stated with the estimate: 40%); middle value at least 1.1-fold (0.05 log units) from the limit.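

In this assay compound 1 and compound 4 both stand at a limit, so no step between them can be read: the limit of > 400 mL.min-1.g-1 in this assay, at which 2 of the 4 values shown sit.

The compounds shown leave open whether cyclopropyl in place of chloro on an aromatic carbon changes the read-out at all.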